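Adding a Methyl on the Amide Side Chain

This account rests on a few compounds, and the source may have more. Where it says the series, first, only, none or still open, it means among the compounds named here.

Compound 1 `CC(C)OC(=O)N1CCC(n2ncc3cc(-c4ccc(S(C)(=O)=O)cc4)ncc32)CC1` and compound 2 `CC(C)(C)OC(=O)N1CCC(n2ncc3cc(-c4ccc(S(C)(=O)=O)cc4)ncc32)CC1` share one core, while compound 3 `CCNC(=O)c1cc(F)c(-c2cc3cnn(C4CCN(C(=O)OC(C)C)CC4)c3cn2)cc1F` and compound 4 `CCCNC(=O)c1cc(F)c(-c2cc3cnn(C4CCN(C(=O)OC(C)C)CC4)c3cn2)cc1F` share another; the difference between the two cores is not broken down here. In a functional assay on HEK293 cells for agonist activity at Glucose-dependent insulinotropic receptor (Homo sapiens), read by cAMP accumulation, with a stated time of 30 min (a higher number here means that more compound is needed for the effect, a lower number that less compound is needed), compound 1 gives 42 nM, and compound 2 gives 20 nM, so the change methyl in place of hydrogen on a saturated chain carbon bound to an oxygen next to a carbonyl group and two saturated chain carbons made a 2.1-fold lower number from compound 1 to compound 2 (0.32 log units; beyond the scatter). In this assay compound 3 gives 10 nM, within the scatter of compound 2 and beyond it from compound 1. Compound 4 carries the same kind of change, (methyl in place of hydrogen on a saturated chain carbon, two bonds along the chain from an amide-type nitrogen), but at a different place: on a saturated chain carbon, two bonds along the chain from an amide-type nitrogen, rather than on a saturated chain carbon bound to an oxygen next to a carbonyl group and two saturated chain carbons. Because the earlier step of a 2.1-fold lower number from compound 1 to compound 2 (0.32 log units; beyond the scatter) was modest and the surroundings differ, only a small step of a 1.3-fold lower number from compound 3 to compound 4 (0.10 log units; within the scatter) is expected. Compound 4 is therefore estimated at 8 nM, likely between 3 nM and 20 nM.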

Compound 4, half-maximal effective concentration: 14 nM
Estimate against measurement, compound 4: 1.8-fold (0.24 log units) below; low and high end bracket the measured number.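

On the amide side chain, methyl in place of hydrogen turns ethylamino into propylamino, and in this assay this gives a 1.4-fold higher number from compound 3 to compound 4 (0.15 log units; within the scatter), so no real change can be read from this step. Set beside the earlier step, the effect of adding a methyl did not carry over from one core to the other: the same change on two cores in this assay, a 2.1-fold lower number (0.32 log units; beyond the scatter) from compound 1 to compound 2 and a 1.4-fold higher number (0.15 log units; within the scatter) from compound 3 to compound 4, 2.9-fold (0.47 log units) apart, beyond the scatter of two such steps

This does not show whether the core or the place of the methyl separates the two steps, as the methyl sits at a different place in each pair. The compounds shown leave open what a longer chain, such as butyl, or a carboxylic acid on the amide side chain would do. They also leave open whether the methyl added in compound 2 would give the same step on the core of compound 3.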